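The source may hold more compounds than are shown below. What is called first, only, known or untested is meant among the compounds shown, and "the series" means these compounds.

In a functional assay on PC-9 cells (Homo sapiens) for inhibition, read by MTT assay, with a stated time of 72 h (on this read-out higher numbers stand for weaker inhibition and lower numbers for stronger inhibition), compound 1 `Cc1cc(Nc2ccn(Cc3ccccc3)n2)n2nc(SCc3ccc(Br)cc3)nc2n1` gives > 50000 nM as a limit of the assay. Compound 2 `Cc1cc(Nc2ccn(Cc3csc4ccc(Cl)cc34)n2)n2nc(SCc3ccc(Br)cc3)nc2n1` gives 4350 nM as a measured number. Compound 3 `COc1ccc(Cn2ccc(Nc3cc(C)nc4nc(SCc5ccc(Br)cc5)nn34)n2)cc1` gives > 50000 nM as a limit too, which places it at the limit of > 50000 nM in this assay, at which 2 of the 3 values shown sit.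

Compound 4 `Cc1ccc(Cn2ccc(Nc3cc(C)nc4nc(SCc5ccc(Br)cc5)nn34)n2)cc1` carries methyl in place of methoxy on an aromatic carbon, para to a large group: methyl in place of methoxy on an aromatic carbon.

The nearest measured change, a step that the two limits leave unreadable from compound 1 to compound 3, is methoxy in place of hydrogen on an aromatic carbon, and its size cannot be read. The large steps, an at least 11-fold lower number from compound 1 to compound 2 (1.06 log units; beyond the scatter) and an at least 11-fold higher number from compound 2 to compound 3 (1.06 log units; beyond the scatter), both involve the 5-chloro-1-benzothiophen-3-yl group, which compound 4 lacks. No step beyond the scatter is therefore expected in this assay, and a report at the limit is the likeliest outcome. The expected change, an at least 1.1-fold lower number from compound 3 to compound 4 (0.04 log units; that floor lies within the scatter), is only an estimate. For compound 4 the estimated value is 45000 nM, with an expected range from 15000 nM to 90000 nM.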

Compound 4, half-maximal inhibitory concentration: > 50000 nM
Compound 4 was reported as a limit (the forecaster's own chance of this, stated with the estimate: 70%); middle value at least 1.1-fold (0.04 log units) away from the limit.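

In this assay compound 4 gives > 50000 nM, which is a limit of the assay. Methyl on the aromatic carbon para to a large group thus joins methoxy and hydrogen at this limit, and the steps among compound 1, compound 3 and compound 4 cannot be read. The 4-methylphenyl group gives a large step, an at least 11-fold higher number from compound 2 to compound 4 (1.06 log units; beyond the scatter), as the 4-methoxyphenyl group does, so the only measured number stays with the 5-chloro-1-benzothiophen-3-yl group, and the limit is now shared more widely: the limit of > 50000 nM in this assay, at which 3 of the 4 values shown sit.

From the compounds shown here alone, how far any of these three benzyl compounds lies past the limit remains unknown, so methyl, methoxy and hydrogen cannot be ranked on this carbon. Going by these compounds, whether chlorine, a hydroxyl or an amine on this carbon would bring a benzyl compound to a measurable number remains open.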